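Swapping methoxy for fluoro on two related cores

A few compounds are considered here, and "the series" means these few. Any claim that something is new, unique, unknown or untested is made for them only; others in the source may bear on it.

Compound 1 `COc1ccc(N2C(=O)COc3ccc(-c4cnc(Cl)c(NS(=O)(=O)c5ccc(F)cc5)c4)cc32)cc1` carries a methoxy on an aromatic carbon para to a large group. In a functional assay on HeLa cells (Homo sapiens) for antiproliferative activity, read by MTT assay, with a stated time of 72 h (on this read-out lower numbers stand for stronger inhibition and higher numbers for weaker inhibition), compound 1 gives 8320 nM. Compound 2 `O=C1COc2ccc(-c3cnc(Cl)c(NS(=O)(=O)c4ccc(F)cc4)c3)cc2N1c1ccc(F)cc1` differs from it by fluoro in place of methoxy on an aromatic carbon. Compound 2 reaches only a limit of the assay, > 40000 nM, and not a number. The step of an at least 4.8-fold higher number from compound 1 to compound 2 (0.68 log units; beyond the scatter) therefore runs toward weaker inhibition.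

Compound 3 `COc1ccc(N2C(=O)COc3ccc(-c4cnc5ccccc5c4)cc32)cc1` rests on a different core, and the difference between the two cores is not broken down here. Compound 3 also sits at a limit of the assay, > 40000 nM. Compound 4 `O=C1COc2ccc(-c3cnc4ccccc4c3)cc2N1c1ccc(F)cc1`, not yet measured, differs from compound 3 by fluoro in place of methoxy on an aromatic carbon, the same change at the same place as between compound 1 and compound 2. Because the limit of > 40000 nM in this assay, at which 2 of the 3 values shown sit, already holds compound 3, and because the earlier step of an at least 4.8-fold higher number from compound 1 to compound 2 (0.68 log units; beyond the scatter) went toward weaker inhibition, compound 4 is expected to give 60000 nM, most likely again as a limit rather than a number. The expected step that the limit leaves unreadable from compound 3 to compound 4 is estimated to be flat or toward weaker inhibition, with a range from 30000 nM to 150000 nM.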

Compound 4, half-maximal inhibitory concentration: 38800 nM
For compound 4 the middle estimate is 1.5-fold (0.19 log units) above the measured one; measured number inside the range.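

In this assay, changing 4-methoxyphenyl to 4-fluorophenyl on the core of compound 3 gives an at least 1.0-fold lower number from compound 3 to compound 4 (0.01 log units; that floor lies within the scatter), and this does not repeat the clear loss seen with the same change on the core of compound 1: the same change on two cores in this assay, an at least 4.8-fold higher number (0.68 log units; beyond the scatter) from compound 1 to compound 2 and an at least 1.0-fold lower number (0.01 log units; that floor lies within the scatter) from compound 3 to compound 4, at least 4.9-fold (0.69 log units) apart, beyond the scatter of two such steps. The effect of this change therefore does not carry over unchanged between these two cores, although each step rests on one compound held at a limit of the assay, so neither step has an exact size. On these data alone, it also remains unknown how far compound 3 lies from compound 4, or why the two cores respond differently, and much of the readable range on this core is lost to the limit: the limit of > 40000 nM in this assay, at which 2 of the 4 values shown sit.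

The compounds shown leave open how an amine, a hydroxyl or a longer chain such as ethoxy would behave at this same place on either core. With only one pair on each core, they also leave open whether the difference seen here would hold for other pairs in the series.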